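The compounds below may be only part of what the source reports. "The series", "measured", "known", "first", "only" and "open" are said of these compounds alone.

Measured in a functional assay on SW480 cells (Homo sapiens) for antiproliferative activity, read by MTT assay, with a stated time of 48 h; on this read-out higher numbers stand for weaker inhibition and lower numbers for stronger inhibition:
- compound 1 `CC(C)=CCC[C@]1(C)/C=C/[C@@H](OC(=O)C=C(C)C)[C@](C)(O)/C=C/C(=O)/C(CN2CCN(C)CC2)=C\C1`: 800 nM
- compound 2 `CC(C)=CCC[C@]1(C)/C=C/[C@@H](OC(=O)C=C(C)C)[C@](C)(O)/C=C/C(=O)/C(Cn2cc(CO)nn2)=C\C1`: 2870 nM
- compound 3 `CO/N=C/C1=C/C[C@](C)(CCC=C(C)C)/C=C/[C@@H](OC(=O)C=C(C)C)[C@](C)(O)/C=C/C1=O`: 2630 nM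

Compound 3 sits level with compound 2, as a 1.1-fold lower number from compound 2 to compound 3 (0.04 log units; within the scatter) shows, while compound 1 stands apart, with a 3.3-fold higher number from compound 1 to compound 3 (0.52 log units; beyond the scatter). Compound 4 `CC(C)=CCC[C@]1(C)/C=C/[C@@H](OC(=O)C=C(C)C)[C@](C)(O)/C=C/C(=O)/C(C(=O)N2CCCC2)=C\C1` carries a (pyrrolidin-1-yl)carbonyl group on the double-bonded ring carbon: a group of 7 heavy atoms (5 carbon, 1 nitrogen, 1 oxygen; one five-membered non-aromatic ring with 1 hetero atom) in place of a group of 4 heavy atoms (2 carbon, 1 nitrogen, 1 oxygen; no ring), on a double-bonded ring carbon. Exchanges at this carbon gave a 3.6-fold higher number from compound 1 to compound 2 (0.55 log units; beyond the scatter), and the modest size of that step and of the one to compound 3 sets the largest shift seen. Only compound 1 departs from the other two, and compound 4 lacks its 4-methylpiperazin-1-yl group. In this assay the expected result is therefore a 1.1-fold lower number from compound 3 to compound 4 (0.02 log units; within the scatter), with no shift beyond the scatter anticipated. For compound 4 the estimated value is 2500 nM, with an expected range of 900 nM to 7000 nM.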

Compound 4, half-maximal inhibitory concentration: 15100 nM
Beside the measured number, compound 4's estimate is 6.0-fold (0.78 log units) below it; the whole stated range lies below it.
By their numbers in this assay, from the lowest: compound 1; then compounds 3 and 2 (each within the scatter of the next); then compound 4.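

In this assay the (pyrrolidin-1-yl)carbonyl group gives the weakest inhibition of the set, with a 5.7-fold higher number from compound 3 to compound 4 (0.76 log units; beyond the scatter) and a 5.3-fold higher number from compound 2 to compound 4 (0.72 log units; beyond the scatter), so groups lacking the 4-methylpiperazin-1-yl unit are not interchangeable at this double-bonded ring carbon, although compounds 2 and 3 alone had sat level. The span at this carbon also widens, with a 19-fold higher number from compound 1 to compound 4 (1.28 log units; beyond the scatter) as the largest step seen. No measurement offered here accounts for this shift. As far as these compounds go, what a (pyrrolidin-1-yl)methyl group would give at this carbon stays open, and with it whether the higher number goes with the carbonyl or with the pyrrolidine ring.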